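The source may hold more compounds than are shown below. What is called first, only, known or untested is meant among the compounds shown, and "the series" means these compounds.

Compound 3 `CCCc1ccc(NC(=O)Nc2c(C(C)C)cccc2C(C)C)cc1` stands second highest of the three numbers in an assay on isolated protein for inhibition of acyl-CoA:cholesterol acyltransferase (Oryctolagus cuniculus) (on this read-out higher numbers stand for weaker inhibition and lower numbers for stronger inhibition), at 38 nM. Compound 1 `CCCCCCCCc1ccc(NC(=O)Nc2c(C(C)C)cccc2C(C)C)cc1` gives 11 nM, and compound 2 `CC(C)c1cccc(C(C)C)c1NC(=O)Nc1ccccc1` gives 910 nM. Compound 4 `CCCCCCc1ccc(NC(=O)Nc2c(C(C)C)cccc2C(C)C)cc1` carries propyl in place of hydrogen on a saturated chain carbon, three bonds along the chain from an aromatic carbon. Among the compounds with values here, two measured steps bear on this: the step of a 24-fold lower number from compound 2 to compound 3 (1.38 log units; beyond the scatter) and the step of a 3.5-fold higher number from compound 1 to compound 3 (0.54 log units; beyond the scatter), which together show the number falling as the chain on the aromatic carbon grows longer, with the larger part of the fall already gained on reaching compound 3; the step of an 83-fold higher number from compound 1 to compound 2 (1.92 log units; beyond the scatter) spans both. The chain of compound 4 lies between those of compound 3 and compound 1. Compound 4 is therefore expected to show a step of a 2.5-fold lower number from compound 3 to compound 4 (0.40 log units; beyond the scatter), toward a lower number. The estimate for compound 4 in this assay is 15 nM, with a range from 7 nM to 35 nM.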

Compound 4, half-maximal inhibitory concentration: 26 nM
The estimate for compound 4 lay 1.7-fold (0.24 log units) below the measured number; the measured number falls inside the stated range.
By their numbers in this assay, from the lowest: compound 1; then compounds 4 and 3 (each within the scatter of the next); then compound 2.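

In this assay, hexyl in place of hydrogen on the aromatic carbon gives a 35-fold lower number from compound 2 to compound 4 (1.54 log units; beyond the scatter), yet the further propyl on the saturated chain carbon gives only a 1.5-fold lower number from compound 3 to compound 4 (0.16 log units; within the scatter), a step within the scatter. Octyl is separated from hexyl by a 2.4-fold higher number from compound 1 to compound 4 (0.37 log units; beyond the scatter), a modest step, so the four compounds show no even change with each added carbon. Nothing available explains these steps. Going by these compounds, whether a longer chain such as decyl would lower the number further remains open, as does how a chain carrying an amine or a carboxylic acid would read.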